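Cytotoxicity notes: aryl variation on the amine substituent

A few compounds are considered here, and "the series" means these few. Any claim that something is new, unique, unknown or untested is made for them only; others in the source may bear on it.

Measured in a toxicity assay on MDCK cells (Canis lupus familiaris) for cytotoxicity, read by crystal violet staining, with a stated time of 48 h; a lower number here means that less compound is tolerated, a higher number that more compound is tolerated:
compound 1 `Cc1ccc2[nH]c(=O)c(CN(Cc3ccc(C(C)(C)C)cc3)[C@H](CO)c3ccccc3)cc2c1` gives > 10000 nM, a limit.
compound 2 `Cc1ccc2[nH]c(=O)c(CN(Cc3ccc(C(C)(C)C)cc3)C(C)c3ccc(F)cc3)cc2c1` gives > 33000 nM, a limit.
compound 3 `Cc1ccc2[nH]c(=O)c(CN(Cc3ccc(C(C)(C)C)cc3)C(C)c3ccc(OC(F)F)cc3)cc2c1` gives > 5000 nM, a limit.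

Compound 3 stands at a limit only (the limit of > 5000 nM in this assay, at which 1 of the 3 values shown sits). The other two values are limits as well the limit of > 10000 nM in this assay, at which 1 of the 3 values shown sits (the limit of > 33000 nM in this assay, at which 1 of the 3 values shown sits), so the steps a step that the two limits leave unreadable from compound 1 to compound 2, a step that the two limits leave unreadable from compound 1 to compound 3 and a step that the two limits leave unreadable from compound 2 to compound 3 cannot be read. Compound 4 `COc1ccc(C(C)N(Cc2ccc(C(C)(C)C)cc2)Cc2cc3cc(C)ccc3[nH]c2=O)cc1Cl` carries 3-chloro-4-methoxyphenyl in place of 4-(difluoromethoxy)phenyl on a saturated chain carbon bound to an amine nitrogen and a saturated chain carbon. For the measured compounds named here, no measured step bears on this change in a readable way; all three known values sit at limits, so no shift beyond the scatter is expected in this assay. Compound 4 is therefore expected to remain tolerated up to the reported limit, with the step that the limit leaves unreadable from compound 3 to compound 4 estimated as flat. Compound 4 is estimated at 20000 nM, between 5000 nM and 80000 nM.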

Compound 4, half-maximal cytotoxic concentration: > 10000 nM
Compound 4: no number, only a limit (the forecaster's own chance of this, stated with the estimate: 70%); the middle value is on the limit's open side.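

Compound 4 gives only a limit, as do compound 1, compound 2 and compound 3, and no step among these four can be read. The compounds shown leave open where any of them turns cytotoxic and whether the aryl changes shift that concentration.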